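A few compounds are considered here, and "the series" means these few. Any claim that something is new, unique, unknown or untested is made for them only; others in the source may bear on it.

Measured so far, in a functional assay on MDA-MB-435 cells (Homo sapiens) for inhibition, read by sulforhodamine B assay, with a stated time of 48 h; a lower number here means a stronger inhibitor, a higher number a weaker inhibitor:
Compound 1, `COc1cc(-c2nn(-c3cccc(NC(=O)Nc4ccc(Cl)c(Cl)c4)c3)cc2-c2ccncc2)ccc1Cl`, gives 940 nM.
Compound 2, `O=C(Nc1cccc(-n2cc(-c3ccncc3)c(-c3ccc(Cl)c(O)c3)n2)c1)Nc1ccc(Cl)c(Cl)c1`, gives 1100 nM.
Compound 3, `COc1cc(-c2nn(-c3cccc(NC(=O)c4ccc(Cl)c(C(F)(F)F)c4)c3)cc2-c2ccncc2)ccc1Cl`, gives 660 nM.

Compound 2 sits at the high end of these three numbers, though its gaps to compound 1 and compound 3 both lie within the scatter, so none of the three stands apart. Compound 4, `O=C(Nc1cccc(-n2cc(-c3ccncc3)c(-c3ccc(Cl)c(O)c3)n2)c1)Nc1ccc(Cl)c(C(F)(F)F)c1`, keeps the shared core of compound 2 and differs only in this: trifluoromethyl in place of chloro on an aromatic carbon. Among the compounds with values here, the one measured step that touches this change is a 1.4-fold lower number from compound 1 to compound 3 (0.15 log units; within the scatter), which swaps the same pair of groups but alters the amide at the same time and still stays within the scatter. The step of a 1.2-fold higher number from compound 1 to compound 2 (0.07 log units; within the scatter) concerns another position and does not bear on it. The expectation for compound 4 is therefore a step of a 1.3-fold lower number from compound 2 to compound 4 (0.11 log units; within the scatter), not beyond the scatter. Compound 4 is estimated at 850 nM, within 420 nM to 1700 nM.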

Compound 4, half-maximal inhibitory concentration: 660 nM
The estimate for compound 4 lay 1.3-fold (0.11 log units) above the measured number; the measured number falls inside the stated range.
By their numbers in this assay, from the lowest: compounds 3, 4, 1 and 2 (each within the scatter of the next).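

Earlier, this exchange appeared only together with a change in the amide, so its own contribution could not be separated. Here it stands alone on an aromatic carbon ortho to a chloro group, giving a 1.7-fold lower number from compound 2 to compound 4 (0.22 log units; within the scatter) in this assay, so a group of four heavy atoms can replace a single chlorine at this position without moving the number beyond the scatter. Nothing available explains this result.

Still open, on these data alone, is how a nitrile, an amine or a carboxylic acid on this carbon would read. So is whether the exchange behaves the same way in the urea carrying the methoxy group of compound 1.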